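Swapping Trifluoromethyl for Methoxy in a Small Series

The source may report more compounds than this note shows. Statements on the series, on what has been measured and on what is new or still open speak of the compounds shown alone.

Three measured compounds share one core. In a functional assay on PC-12 cells (Rattus norvegicus) for cytotoxicity, read by MTT assay, with stated times of 2 h and 24 h, tested at 5 uM (on this read-out lower numbers stand for a weaker effect and higher numbers for a stronger effect at the one concentration tested), compound 1 `Oc1cc(C(F)(F)F)ccc1-c1nc(-c2ccccc2O)n(-c2ccc(C(F)(F)F)cc2)n1` gives 90.5%. Compound 2 `COc1ccc(-n2nc(-c3ccc(C(F)(F)F)cc3O)nc2-c2ccccc2O)cc1` gives 86.6% in this assay, and compound 3 `Oc1cc(C(F)(F)F)ccc1-c1nc(-c2ccccc2O)n(-c2ccccc2C(F)(F)F)n1` gives 80% in this assay. The change from compound 1 to compound 2 is methoxy in place of trifluoromethyl on an aromatic carbon, and the step was a number 3.9 percentage points lower from compound 1 to compound 2 (within the scatter). The cores of compound 1 and compound 3 differ by 2-(trifluoromethyl)phenyl in place of 4-(trifluoromethyl)phenyl on an aromatic nitrogen, with a step of a number 10.5 percentage points lower from compound 1 to compound 3 (beyond the scatter); the step of a number 6.6 percentage points lower from compound 2 to compound 3 (within the scatter) followed.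

Compound 4 `COc1ccccc1-n1nc(-c2ccc(C(F)(F)F)cc2O)nc1-c1ccccc1O` has not yet been measured. It differs from compound 3 by methoxy in place of trifluoromethyl on an aromatic carbon. This is the same kind of change as that made from compound 1 to compound 2, though not the same: there the place was para to a large group, here it is ortho to a large group. A small step is expected in this assay, because the earlier step of a number 3.9 percentage points lower from compound 1 to compound 2 (within the scatter) lay within the scatter. Compound 4 is expected to differ from compound 3 by a number 4 percentage points lower from compound 3 to compound 4 (within the scatter). Compound 4 is therefore estimated at 76% in this assay, with a likely range from 66% to 86%.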

Compound 4, a percentage reported as activity, at one concentration (the size of the read-out at that concentration, not a potency): 85.6%
Compound 4: middle estimate off by 9.6 percentage points, on the low side; the range from low to high includes it.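

In this assay, the two steps for methoxy in place of trifluoromethyl can be set side by side, and they do not differ by more than repeated measurements would: the same change on two cores in this assay, a number 3.9 percentage points lower (within the scatter) from compound 1 to compound 2 and a number 5.6 percentage points higher (within the scatter) from compound 3 to compound 4, 9.5 percentage points apart, within the scatter of two such steps. The new compound also stays close to the other two, with a step of a number 1 percentage points lower from compound 2 to compound 4 (within the scatter) and another of a number 4.9 percentage points lower from compound 1 to compound 4 (within the scatter). So the change can be carried between these two cores with only a small step on each, a number 5.6 percentage points higher from compound 3 to compound 4 (within the scatter) being the newer one, but two pairs do not show that it would stay small on any further core, and they do not settle a direction for the step.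

The compounds shown leave open what an amine, a carboxylic acid or a longer chain would do on an aromatic carbon of this ring. With one concentration behind every number, they speak only of a stronger or weaker effect at that concentration and leave open how the compounds would compare at any other.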